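A few compounds are considered here, and "the series" means these few. Any claim that something is new, unique, unknown or untested is made for them only; others in the source may bear on it.

Within a functional assay on DU-145 cells (Homo sapiens) for inhibition, read by trypan blue exclusion, with a stated time of 96 h (a higher number here means a weaker inhibitor of growth, a lower number a stronger inhibitor of growth), compound 2 `O=C(O)c1ccc(C(=O)/C(=C\c2ccc(Br)cc2)SCc2ccc(Br)cc2)cc1` gives 1000 nM, the lowest of the two plain numbers recorded. Its nearest neighbour is compound 1 `COc1ccc(/C=C(/SCc2ccc(Cl)cc2)C(=O)c2ccc(Br)cc2)cc1`, which gives 10000 nM, a gap beyond the usual scatter. Compound 3 `O=C(/C(=C\c1ccc(O)c([N+](=O)[O-])c1)SCc1ccc(Br)cc1)c1ccc(O)cc1O` yields only a limit in this assay, > 100000 nM, which is the limit of > 100000 nM in this assay, at which 1 of the 3 values shown sits. Compound 4 `COc1cc(/C=C(/SCc2ccc(Br)cc2)C(=O)c2ccc(C(=O)O)cc2)ccc1F` awaits measurement in this assay. Relative to compound 2 it shows (4-fluoro-3-methoxyphenyl in place of 4-bromophenyl on a double-bonded chain carbon bound to a double-bonded chain carbon). For the measured compounds named here, no measured pair isolates this change, so the step is uncertain; the expectation is a modest change from compound 2 to compound 4 a 2.5-fold higher number from compound 2 to compound 4 (0.40 log units; beyond the scatter), probably toward weaker inhibition of growth but possibly no further than the scatter reaches. Compound 4 is therefore estimated at 2500 nM, with a range from 600 nM to 12000 nM.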

Compound 4, concentration for 50% growth inhibition: 1000 nM
Beside the measured number, compound 4's estimate is 2.5-fold (0.40 log units) above it; the range from low to high includes it.
By their numbers in this assay, from the lowest: compounds 2 and 4 (each within the scatter of the next); then compound 1. At a limit, above all of these: compound 3.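

In this assay the exchange of 4-bromophenyl for 4-fluoro-3-methoxyphenyl on a double-bonded chain carbon bound to a double-bonded chain carbon gives no change at the digits printed from compound 2 to compound 4 (within the scatter). This first single-place comparison among the compounds shows that this position accepts the group with more heavy atoms and a hydrogen-bond acceptor while growth inhibition holds. Nothing measured here accounts for this result.

Going by these compounds, whether the fluorine or the methoxy alone would give the same reading remains open. So does whether an amine or a longer chain could replace the ring at this position.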